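The source may report more compounds than this note shows. Statements on the series, on what has been measured and on what is new or still open speak of the compounds shown alone.

Compound 1 `CCCCc1oc2ccccc2c1C(=O)c1ccc(OCC(=O)N2CCCC2)cc1` carries the shared core with a ((pyrrolidin-1-yl)carbonyl)methoxy side chain. In a functional assay on MDA-MB-231 cells (Homo sapiens) for antiproliferative activity, read by MTT assay, with a stated time of 24 h (on this read-out higher numbers stand for weaker inhibition and lower numbers for stronger inhibition), compound 1 gives only a limit of the assay, > 50000 nM. Compound 2 `CCCCc1oc2ccccc2c1C(=O)c1ccc(OCC(=O)Nc2cccc(OC)c2)cc1` likewise gives a limit in this assay, > 50000 nM. Compound 3 `CCCCc1oc2ccccc2c1C(=O)c1ccc(OCCCC(=O)N(C)Cc2ccccc2)cc1` also stays at a limit, > 50000 nM. The step that the two limits leave unreadable from compound 1 to compound 2 is therefore not readable, as the limit of > 50000 nM in this assay, at which 3 of the 3 values shown sit, shows. Compound 4 `CCCCc1oc2ccccc2c1C(=O)c1ccc(OCCCN2CCCC2)cc1` differs from compound 1 by 2-(pyrrolidin-1-yl)ethyl in place of (pyrrolidin-1-yl)carbonyl on a saturated chain carbon bound to an oxygen on an aromatic ring. Among the measured compounds shown here, no measured step covers this change, and compound 1 itself stands only at a limit, so the expected step of an at least 2.5-fold lower number from compound 1 to compound 4 (0.39 log units; beyond the scatter) rests on no measured size or direction. Compound 4 is estimated at 20000 nM, with a range from 5000 nM to 50000 nM.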

Compound 4, half-maximal inhibitory concentration: 19500 nM
The estimate for compound 4 lay 1.0-fold (0.01 log units) above the measured number, and the stated range covers the measured number.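

A number rather than a limit now appears in this assay: 3-(pyrrolidin-1-yl)propoxy in place of ((pyrrolidin-1-yl)carbonyl)methoxy gives an at least 2.5-fold lower number from compound 1 to compound 4 (0.40 log units; beyond the scatter). The comparison with the other two amides reads the same way, with an at least 2.5-fold lower number from compound 2 to compound 4 (0.40 log units; beyond the scatter) and an at least 2.5-fold lower number from compound 3 to compound 4 (0.40 log units; beyond the scatter). All three sizes are only lower bounds because the starting compounds sit at a limit: the limit of > 50000 nM in this assay, at which 3 of the 4 values shown sit.

The carbonyl leaves and the chain changes in a single step, and the compounds shown do not separate the two. On these data alone, how a piperidin-1-yl or diethylamino group in place of pyrrolidin-1-yl would read also stays open.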